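Lengthening the Ester Chain and Liver Microsome Stability

The source may report more compounds than this note shows. Statements on the series, on what has been measured and on what is new or still open speak of the compounds shown alone.

Compound 1, `CCCCc1nc(C(C)C)c(CC(=O)OC)c(=O)n1Cc1ccc(-c2ccccc2-c2noc(=O)[nH]2)cc1`; in an ADME assay on microsomes from liver (Homo sapiens) for metabolic stability, with a stated time of 30 min (a lower number here means that less of the compound is left, a higher number that more of the compound is left), compound 1 gives 10.5%.
Compound 2, `CCCCc1nc(C(C)C)c(CC(=O)OCC(F)(F)F)c(=O)n1Cc1ccc(-c2ccccc2-c2noc(=O)[nH]2)cc1`; in this assay compound 2 gives "not determined" (no result reported), so no result was reported for it.
Compound 3, `CCCCOC(=O)Cc1c(C(C)C)nc(CCCC)n(Cc2ccc(-c3ccccc3-c3noc(=O)[nH]3)cc2)c1=O`; in this assay compound 3 gives 7.1%.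
Compound 4, `CCCCCOC(=O)Cc1c(C(C)C)nc(CCCC)n(Cc2ccc(-c3ccccc3-c3noc(=O)[nH]3)cc2)c1=O`; not yet measured in this assay.

Compound 3 and compound 1 share the same core and differ only in the ester chain. Their two numbers sit close together: the step of a number 3.4 percentage points lower from compound 1 to compound 3 (within the scatter), so neither compound can be said to leave more or less behind than the other. Compound 2 offers no number for comparison.

Compound 4 differs from compound 3 by methyl in place of hydrogen on a saturated chain carbon, four bonds along the chain from an oxygen next to a carbonyl group. Going by the values given here, the one measured step of a similar kind, from compound 1 to compound 3, added three carbons to that same chain and stayed within the scatter. Adding a single further carbon is therefore expected to move this assay by no more than the scatter, a step of a number 1.1 percentage points lower from compound 3 to compound 4 (within the scatter). Compound 4 is thus expected to give about 6%, with a likely range from 2% to 14%.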

Compound 4, percent of the compound remaining: 10.6%
For compound 4 the middle estimate is 4.6 percentage points below the measured one; low and high end bracket the measured number.
By their numbers in this assay, from the lowest: compounds 3, 1 and 4 (each within the scatter of the next).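

At the end of the ester chain, methyl in place of hydrogen gives, in this assay, a number 3.5 percentage points higher from compound 3 to compound 4 (within the scatter), so this further carbon cannot be told apart from no change. The longer reach also stays within the scatter: butyl in place of hydrogen on the saturated chain carbon bound to the ester oxygen gives a number 0.1 percentage points higher from compound 1 to compound 4 (within the scatter), so the three esters with a measured number cannot be separated, whatever the length of their straight chains. No supporting measurement is available to explain this result.

Compound 2 has no number, so its fluorine-bearing chain cannot be compared with the others. From the compounds shown here alone, whether a much longer chain, a branched chain, or a chain ending in an amine or a carboxylic acid would leave a different amount of compound behind remains open.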